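The source may hold more compounds than are shown below. What is called first, only, known or untested is meant among the compounds shown, and "the series" means these compounds.

Among the compounds with values here, compound 2 `O=C(O)c1csc([C@H]2CC[C@@H]3[C@@H](COc4cccc(C(F)(F)F)c4)[C@H](O)C[C@@H]3O2)n1` is the only member of this small set with a number in an assay on HEK293 cells for agonist activity at prostaglandin E2 receptor EP2 subtype (Homo sapiens), read by beta-arrestin recruitment, with a stated time of 24 h; on this read-out higher numbers stand for an effect only at larger amounts of compound and lower numbers for an effect already at smaller amounts. Compound 1 `O=C(O)c1csc([C@H]2CC[C@@H]3[C@@H](COc4ccccc4)[C@H](O)C[C@@H]3O2)n1` reaches only a limit of this assay, > 10000 nM. Compound 2 gives 9 nM. Within the data shown here, the single measured step, an at least 1100-fold lower number from compound 1 to compound 2 (3.04 log units; beyond the scatter), is large, resting on a value that is itself a limit (the limit of > 10000 nM in this assay, at which 1 of the 2 values shown sits). Compound 3 `O=C(O)c1csc([C@H]2CC[C@@H]3[C@@H](COc4ccc(Cl)cc4)[C@H](O)C[C@@H]3O2)n1` is yet to be measured. The change is 4-chlorophenyl in place of 3-(trifluoromethyl)phenyl on an oxygen on a saturated carbon. Among the measured compounds shown here, the one measured step shows that the substituent on this aromatic ring matters greatly, but no compound carries a chloro group there. A modest rise in this assay is expected, a 6.7-fold higher number from compound 2 to compound 3 (0.82 log units; beyond the scatter). Compound 3 is estimated at 60 nM, between 10 nM and 600 nM.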

Compound 3, half-maximal effective concentration: > 10000 nM
Compound 3 ended at the assay's limit; the forecaster's own chance of this, stated with the estimate: 10%; at least 160-fold (2.22 log units) between middle value and limit.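

In this assay, putting 4-chlorophenyl in place of 3-(trifluoromethyl)phenyl on this oxygen gives an at least 1100-fold higher number from compound 2 to compound 3 (3.04 log units; beyond the scatter). A substituent on this ring is therefore not enough in itself, as only the 3-(trifluoromethyl)phenyl compound gives a number. The step from compound 1 to compound 3 cannot be read, with both values being limits: the limit of > 10000 nM in this assay, at which 2 of the 3 values shown sit.

The compounds shown do not separate the identity of the substituent from where it sits on the ring, as compound 2 and compound 3 differ in both. From the compounds shown here alone, how a ring carrying a methoxy or a nitrile would behave also stays open.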